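Compound 4: a trifluoro side chain under test

The source may report more compounds than this note shows. Statements on the series, on what has been measured and on what is new or still open speak of the compounds shown alone.

In an in vitro ADME assay on microsomes from Gut (Homo sapiens) for metabolic stability, in the presence of a further agent that is not named here (on this read-out lower numbers stand for slow clearance and higher numbers for fast clearance), compound 3 (`CC(C)(O)CCNC(=O)c1cc2cc(C#N)ccc2n1Cc1cccc(OC(F)(F)F)c1`) gives 9 mL.min-1.g-1 and holds the lowest of three numbers, under compound 2 (`COc1ccc(OC(F)(F)F)cc1Cn1c(C(=O)NCC2(CO)CC2)cc2cc(C#N)ccc21`) at 51 mL.min-1.g-1 and compound 1 (`CC(C)(CO)CNC(=O)c1cc2cc(C#N)ccc2n1Cc1cccc(OC(F)(F)F)c1`) at 136 mL.min-1.g-1 on the same scale. Compound 4 (`N#Cc1ccc2c(c1)cc(C(=O)NCCC(O)C(F)(F)F)n2Cc1cccc(OC(F)(F)F)c1`) carries 2,2,2-trifluoro-1-hydroxyethyl in place of 1-hydroxy-1-methylethyl on a saturated chain carbon, two bonds along the chain from an amide-type nitrogen. Among the measured compounds shown here, the one measured step on this side chain is a 15-fold lower number from compound 1 to compound 3 (1.18 log units; beyond the scatter) and it shows that the chain can matter greatly, yet no measured compound has fluorine there. The expected step is therefore modest, a 1.6-fold higher number from compound 3 to compound 4 (0.19 log units; within the scatter) as an estimate with a slight upward lean. For compound 4 the estimated value is 14 mL.min-1.g-1 with an expected range from 5 mL.min-1.g-1 to 40 mL.min-1.g-1 in all.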

Compound 4, intrinsic clearance in microsomes: < 6 mL.min-1.g-1
Compound 4: no number, only a limit; the forecaster's own chance of this, stated with the estimate: 10%; at least 2.3-fold (0.36 log units) between middle value and limit.
By their numbers in this assay, from the lowest: compound 3; then compound 2; then compound 1. At a limit, below all of these: compound 4.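

In this assay compound 4 gives only a limit, not a number: the limit of < 6 mL.min-1.g-1 in this assay, at which 1 of the 4 values shown sits. The first fluorinated chain at this position gives an at least 1.5-fold lower number from compound 3 to compound 4 (0.17 log units; that floor lies within the scatter), so the trifluoro change keeps clearance low, although compound 4 cannot be firmly ranked against compound 3. The gap to the other chain is clear, with an at least 22-fold lower number from compound 1 to compound 4 (1.35 log units; beyond the scatter).

Every side chain shown carries a hydroxy group, so its role in this read-out stays open. A chain ending in an amine or a carboxylic acid would test that.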